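The compounds below may be only part of what the source reports. "The series", "measured", "known", "first", "only" and "open" are said of these compounds alone.

Measured so far:
compound 1 `CCCCCCc1nc(O)cc(O)n1` gives 454 nM in a functional assay on HEK293 cells for agonist activity at G-protein coupled receptor 84 (Homo sapiens), read by calcium flux; a lower number here means that less compound is needed, a higher number that more compound is needed for the effect;
compound 2 `CCCCCCCCNc1nc(O)cc(O)n1` gives 6.14 nM in this assay.

Compound 1 stands highest of these two numbers; its nearest neighbour, compound 2, sits far lower, beyond the scatter. Within the data shown here, no step between measured compounds differing in one place is available. Compound 3 `CCCCCc1nc(O)cc(O)n1` arises from compound 1 by hydrogen in place of methyl on a saturated chain carbon, five bonds along the chain from an aromatic carbon. The step is expected to be modest and to raise the number, since compound 2, with its longer chain, gives 6.14 nM. Compound 3 is expected near 1200 nM, within 400 nM to 4000 nM. This corresponds to an expected step of a 2.6-fold higher number from compound 1 to compound 3 (0.42 log units; beyond the scatter).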

Compound 3, half-maximal effective concentration: 3670 nM
Compound 3: middle estimate off by 3.1-fold (0.49 log units), on the low side; low and high end bracket the measured number.
By their numbers in this assay, from the lowest: compound 2; then compound 1; then compound 3.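

In this assay, hydrogen in place of methyl on a saturated chain carbon, five bonds along the chain from an aromatic carbon, brings an 8.1-fold higher number from compound 1 to compound 3 (0.91 log units; beyond the scatter). Among these compounds, this is the first direct reading of this position: with the rest of the molecule unchanged, the loss of one carbon moves the number beyond the scatter. No measurement at hand explains the size of this step. On these data alone, what a longer chain does on the core of compound 1 remains open. So does the effect of an amine or a carboxylic acid at this position.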